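Nitrooxy to Trifluoromethyl on the Sulfonyl Aryl Ring

The compounds below may be only part of what the source reports. "The series", "measured", "known", "first", "only" and "open" are said of these compounds alone.

The study compares four compounds built on two closely related cores. Compound 1 `O=C1/C(=C/c2cccc(F)c2)CN(S(=O)(=O)c2ccc(O[N+](=O)[O-])cc2)C/C1=C\c1cccc(F)c1` and compound 2 `O=C1/C(=C/c2cccc(F)c2)CN(S(=O)(=O)c2ccc(C(F)(F)F)cc2)C/C1=C\c1cccc(F)c1` share one core; compound 3 `O=C1/C(=C/c2ccc(F)cc2)CN(S(=O)(=O)c2ccc(O[N+](=O)[O-])cc2)C/C1=C\c1ccc(F)cc1` and compound 4 `O=C1/C(=C/c2ccc(F)cc2)CN(S(=O)(=O)c2ccc(C(F)(F)F)cc2)C/C1=C\c1ccc(F)cc1` share the other. The difference between the two cores is not broken down here.

All measured compounds were tested in a functional assay on HepG2 cells (Homo sapiens) for cytotoxicity, read by MTT assay, with a stated time of 24 h; on this read-out lower numbers stand for stronger inhibition and higher numbers for weaker inhibition. Compound 1 gives 8100 nM, and compound 2 gives 2400 nM. The change from compound 1 to compound 2 is trifluoromethyl in place of nitrooxy on an aromatic carbon, and it made a step of a 3.4-fold lower number from compound 1 to compound 2 (0.53 log units; beyond the scatter). Compound 3 gives 5400 nM; this value and that of compound 1 lie within the scatter of one another, so no order between the two is claimed.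

Compound 4 has not yet been measured in this assay. Compound 4 differs from compound 3 by trifluoromethyl in place of nitrooxy on an aromatic carbon, which is the same change, at the same kind of place, as that from compound 1 to compound 2. Among the compounds with values here, on that basis a step of similar size is expected from compound 3 to compound 4, estimated at a 3.0-fold lower number from compound 3 to compound 4 (0.48 log units; beyond the scatter), because the single measured example of this change is a 3.4-fold lower number from compound 1 to compound 2 (0.53 log units; beyond the scatter). For compound 4 the expected value is therefore 1800 nM. The lower end of that expectation for compound 4 is 800 nM. The upper end expected for compound 4 is estimated at 4000 nM. Within the data shown here, with only one prior example of the change, on a different core, the range is kept wide.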

Compound 4, half-maximal inhibitory concentration: 3200 nM
Compound 4: the middle estimate sits 1.8-fold (0.25 log units) below what was measured, within the range that was stated.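

In this assay, the exchange of 4-(nitrooxy)phenyl for 4-(trifluoromethyl)phenyl on the core of compound 3 gives a 1.7-fold lower number from compound 3 to compound 4 (0.23 log units; within the scatter), so on this core the step alone cannot be told apart from repeat measurement. Set beside the earlier step, it does not differ from it by more than such steps scatter: the same change on two cores in this assay, a 3.4-fold lower number (0.53 log units; beyond the scatter) from compound 1 to compound 2 and a 1.7-fold lower number (0.23 log units; within the scatter) from compound 3 to compound 4, 2.0-fold (0.30 log units) apart, within the scatter of two such steps. Within the data shown here, the two cores therefore give no sign that the change behaves differently from one to the other, but this does not show that it carries over at a fixed size, as only the step on the core of compound 1 stands beyond the scatter, and two pairs say nothing about a third core.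

The compounds shown leave open how other groups in the same place on the sulfonyl aryl ring, such as an amine, a carboxylic acid or a nitrile, would read in this assay. They also leave open whether the exchange would give a step of like size on a core with chlorine or a methoxy group in place of the fluorine.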